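Carbamate-to-thiocarbamate switch at the piperidine nitrogen

The compounds below may be only part of what the source reports. "The series", "measured", "known", "first", "only" and "open" are said of these compounds alone.

Measured so far:
compound 1 `Cc1nc(S(C)(=O)=O)ccc1Oc1ncnc(OC2CCN(C(=O)O[C@H](C)C(F)(F)F)CC2)c1F` — 110 nM
compound 2 `Cc1nc(S(C)(=O)=O)ccc1Oc1ncnc(OC2CCN(C(=O)OC3COC3)CC2)c1F` — 2500 nM

In a functional assay on isolated protein for inhibition of Glucose-dependent insulinotropic receptor (Rattus norvegicus), read by HTRF and cAMP accumulation (a higher number here means that more compound is needed for the effect, a lower number that less compound is needed), compound 2 gives 2500 nM, the highest of the two numbers recorded; its nearest neighbour is compound 1, and the step of a 23-fold higher number from compound 1 to compound 2 (1.36 log units; beyond the scatter) separates them. Compound 3 `Cc1nc(S(C)(=O)=O)ccc1Oc1ncnc(OC2CCN(C(=O)SC(C)C)CC2)c1F` is the next member and has not been measured in this assay. Relative to compound 2 the change is isopropylsulfanyl in place of (oxetan-3-yl)oxy on a carbonyl carbon. Among the compounds with values here, only one measured step bears on this position, a 23-fold higher number from compound 1 to compound 2 (1.36 log units; beyond the scatter), which shows that the group on the oxygen of the carbamate moves the number far beyond the scatter. Compound 3 removes the oxetane ring that entered in that step and replaces the oxygen with sulfur carrying an isopropyl group, a branched three-carbon chain of similar size to the 1-(trifluoromethyl)ethyl group of compound 1. Within the data shown here, a lower number than compound 2 is therefore expected, though not necessarily a full return to compound 1, since the sulfur-for-oxygen exchange has no precedent here. The expected step from compound 2 to compound 3 is a 6.3-fold lower number from compound 2 to compound 3 (0.80 log units; beyond the scatter). For compound 3 in this assay the estimate is 400 nM, with a range from 120 nM to 1300 nM.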

Compound 3, half-maximal effective concentration: 41.3 nM
Estimate against measurement, compound 3: 9.7-fold (0.99 log units) above; measured number below the stated range.
By their numbers in this assay, from the lowest: compound 3; then compound 1; then compound 2.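

In this assay, isopropylsulfanyl on the carbonyl carbon gives a 61-fold lower number from compound 2 to compound 3 (1.78 log units; beyond the scatter), so this position accepts a sulfur-linked group and the high number of compound 2 is not a general feature of replacing the group of compound 1. The sulfur-linked group does more than recover the lost ground: a 2.7-fold lower number from compound 1 to compound 3 (0.43 log units; beyond the scatter) is a modest step but lies beyond the scatter, and it leaves compound 3 with the lowest number of the three. The data give no measured reason for either step.

Each step changes the linking atom and the group it carries together, so the shares of the sulfur and of the isopropyl remain unseparated, and isopropoxy on the same carbonyl carbon would be the direct comparison. Also open, as far as these compounds go, is whether the trend continues with 1-(trifluoromethyl)ethylsulfanyl, which would pair the sulfur with the group of compound 1, or with a longer chain such as butylsulfanyl, and whether a nitrogen link such as isopropylamino fits this position at all.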